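Swapping a cyclohexyl for a methoxy on a benzoylguanidine

The compounds below may be only part of what the source reports. "The series", "measured", "known", "first", "only" and "open" are said of these compounds alone.

Measured so far:
compound 1, `CCN(CC)Cc1cc(Br)c(S(C)(=O)=O)cc1C(=O)N=C(N)N`, 9500 nM
compound 2, `Cc1cc(C2CCCCC2)c(S(C)(=O)=O)cc1C(=O)N=C(N)N`, 22 nM

Both were tested in a functional assay for inhibition of sodium/hydrogen exchanger (Oryctolagus cuniculus); a lower number here means a stronger inhibitor, a higher number a weaker inhibitor. Compound 2 gives the lower of the two numbers, and its gap to compound 1 is far beyond the usual scatter; compound 1 differs from it in more than one place, so no single step can be read from that pair.

The next compound, compound 3 with structure `COc1cc(C)c(C(=O)N=C(N)N)cc1S(C)(=O)=O`, is not yet measured. It differs from compound 2 by one change: methoxy in place of cyclohexyl on an aromatic carbon.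

Among the compounds with values here, no measured pair shows this change, so the expectation rests on the change alone. The step of an 11-fold higher number from compound 2 to compound 3 (1.06 log units; beyond the scatter) is expected to go toward a higher number, beyond the scatter. Compound 3 is therefore estimated at 250 nM, with a likely range from 50 nM to 1500 nM.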

Compound 3, half-maximal inhibitory concentration: 16 nM
Beside the measured number, compound 3's estimate is 16-fold (1.19 log units) above it, outside the stated range (below it).
By their numbers in this assay, from the lowest: compounds 3 and 2 (each within the scatter of the next); then compound 1.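

In this assay the swap of cyclohexyl for methoxy gives a 1.4-fold lower number from compound 2 to compound 3 (0.14 log units; within the scatter) and so leaves the two compounds indistinguishable. This aromatic carbon, ortho to a methylsulfonyl group, therefore holds either a non-aromatic ring of 6 heavy atoms or a methoxy of 2 heavy atoms, one without a hydrogen-bond acceptor and one with, and inhibition stays the same within the scatter. Nothing measured here explains why two such different groups read alike.

Still open, from the compounds shown here alone, is whether this holds for other groups on this carbon, such as an amine, a carboxylic acid or a longer chain. Also open, going by these compounds, is what the methyl group contributes, as compound 1 carries something else there but differs in more than one place.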